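The compounds below may be only part of what the source reports. "The series", "measured", "known", "first", "only" and "open" are said of these compounds alone.

Three compounds of the series have a value in a functional assay on MDA-MB-231 cells (Homo sapiens) for cytotoxicity, read by MTT assay; a lower number here means a stronger inhibitor, a higher number a weaker inhibitor. Compound 1 `CCOc1c(Br)cc(/C=C2\CCC/C(=C\c3cccc([N+](=O)[O-])c3)C2=O)cc1OC` gives 19.3 ug/mL. Compound 2 `CCCOc1c(Br)cc(/C=C2\CCC/C(=C\c3cccc([N+](=O)[O-])c3)C2=O)cc1OC` gives 2.99 ug/mL, and the step of a 6.5-fold lower number from compound 1 to compound 2 (0.81 log units; beyond the scatter) comes from methyl in place of hydrogen on a saturated chain carbon, two bonds along the chain from an oxygen on an aromatic ring. Compound 3 `CCCOc1c(Br)cc(/C=C2\CCC/C(=C\c3ccc([N+](=O)[O-])cc3)C2=O)cc1OC` gives 4.01 ug/mL, with the step of a 1.3-fold higher number from compound 2 to compound 3 (0.13 log units; within the scatter), so compound 3 and compound 2 sit within the scatter of each other. The difference between the cores of compound 1 and compound 3 is not broken down here.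

Compound 4 `CCCCOc1c(Br)cc(/C=C2\CCC/C(=C\c3ccc([N+](=O)[O-])cc3)C2=O)cc1OC` is still to be measured. It differs from compound 3 by methyl in place of hydrogen on a saturated chain carbon, three bonds along the chain from an oxygen on an aromatic ring. Going by the values given here, this is the same kind of change as the one from compound 1 to compound 2, not the same: there the methyl entered two bonds along the chain from an oxygen on an aromatic ring, here three bonds along the chain. Among the compounds with values here, the step of a 6.5-fold lower number from compound 1 to compound 2 (0.81 log units; beyond the scatter) is the only precedent, and a move in the same direction but of smaller size is expected with the change cut one bond further out. Compound 4 is estimated at 2.5 ug/mL in this assay, between 1.2 ug/mL and 5.5 ug/mL. That estimate means a step of a 1.6-fold lower number from compound 3 to compound 4 (0.21 log units; within the scatter).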

Compound 4, half-maximal inhibitory concentration: 8.38 ug/mL
The estimate for compound 4 lay 3.4-fold (0.53 log units) below the measured number; measured number outside the range, above it.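

In this assay, lengthening the chain by one methyl did not carry over from one core to the other: ethyl to propyl gave a 6.5-fold lower number from compound 1 to compound 2 (0.81 log units; beyond the scatter), while propyl to butyl gave a 2.1-fold higher number from compound 3 to compound 4 (0.32 log units; beyond the scatter). Set side by side, the two steps do not agree: the same change on two cores in this assay, a 6.5-fold lower number (0.81 log units; beyond the scatter) from compound 1 to compound 2 and a 2.1-fold higher number (0.32 log units; beyond the scatter) from compound 3 to compound 4, 13-fold (1.13 log units) apart, beyond the scatter of two such steps

This shows that the first step cannot be used as a guide to the second, but it does not show what separates them, since the pair differs both in where the methyl enters the chain and in the presence of 3-nitrophenyl or 4-nitrophenyl on the core.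

The compounds shown leave open how an ethyl chain behaves alongside 4-nitrophenyl and a butyl chain alongside 3-nitrophenyl, and these two pairings would separate chain length from the core. Also open, from the compounds shown here alone, is what a longer chain such as pentyl, or an amine or a carboxylic acid in place of the chain, would give in this assay.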